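Adding a methoxy group to a hydroxamic acid series

This account rests on a few compounds, and the source may have more. Where it says the series, first, only, none or still open, it means among the compounds named here.

In a functional assay on A-431 cells (Homo sapiens) for antiproliferative activity, read by MTT assay, with a stated time of 48 h (on this read-out lower numbers stand for stronger inhibition and higher numbers for weaker inhibition), the three measured compounds gave the following values:

Compound 1 `O=C(CCCCCC(=O)Nc1ccc(O)c(C(=O)Nc2ccc(F)c(Cl)c2)c1)NO`: 3480 nM
Compound 2 `COc1cc(O)c(C(=O)Nc2ccc(F)c(Cl)c2)cc1NC(=O)CCCCCC(=O)NO`: 6460 nM
Compound 3 `C#Cc1cccc(NC(=O)c2cccc(NC(=O)CCCCCC(=O)NO)c2)c1`: 7080 nM

Compound 2 differs from compound 1 in one place, (methoxy in place of hydrogen on an aromatic carbon), and this gave a 1.9-fold higher number from compound 1 to compound 2 (0.27 log units; within the scatter). Compound 3 has a different core from compound 1; how the two cores differ is not broken down here. Compound 4 `C#Cc1cccc(NC(=O)c2cc(NC(=O)CCCCCC(=O)NO)ccc2OC)c1` is compound 3 carrying the same kind of change, (methoxy in place of hydrogen on an aromatic carbon). The surroundings of the place are not identical, since in compound 1 the place is also meta to a hydroxy group (1 heavy atom), which compound 3 does not have. In this assay compound 4 is expected to move by about a 1.4-fold higher number from compound 3 to compound 4 (0.15 log units; within the scatter), an expectation that rests on a 1.9-fold higher number from compound 1 to compound 2 (0.27 log units; within the scatter), while allowing that the step may not carry over exactly on the second core. Compound 4 is therefore estimated to give about 10000 nM, most likely between 4500 nM and 25000 nM.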

Compound 4, half-maximal inhibitory concentration: 4200 nM
For compound 4 the middle estimate is 2.4-fold (0.38 log units) above the measured one; measured number outside the range, below it.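

On the second core, the same swap of hydrogen for methoxy gave a 1.7-fold lower number from compound 3 to compound 4 (0.23 log units; within the scatter) in this assay, and that step, like the earlier 1.9-fold higher number from compound 1 to compound 2 (0.27 log units; within the scatter), is too small on its own to count as a real change. Set side by side, however, the two steps do not agree, so in this series the size and direction of this change cannot simply be copied from one core to the other: the same change on two cores in this assay, a 1.9-fold higher number (0.27 log units; within the scatter) from compound 1 to compound 2 and a 1.7-fold lower number (0.23 log units; within the scatter) from compound 3 to compound 4, 3.1-fold (0.50 log units) apart, beyond the scatter of two such steps What this does not show is why they differ: the core of compound 1 carries a hydroxy group that compound 3 lacks, the cores differ in other ways too, and two steps cannot tell which difference matters.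

The compounds shown leave open whether an ethoxy group or a chlorine atom on that same aromatic carbon would behave like methoxy on each core. They also leave open whether a longer chain in place of the present one would alter the comparison.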